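The source may report more compounds than this note shows. Statements on the series, on what has been measured and on what is new or still open speak of the compounds shown alone.

Compound 1 `O=C(CCCCCc1ccccc1)OCC1COCCOCCOCCOCCOCCO1`: > 100000 nM (a limit)
Compound 2 `O=C(CCCCC1CCCCC1)OCC1COCCOCCOCCOCCOCCO1`: 33000 nM
Compound 3 `O=C(CCCCOc1ccccc1)OCC1COCCOCCOCCOCCOCCO1`: > 100000 nM (a limit)

Three esters share one core and differ only in the terminal group of the acyl chain. In a functional assay on WiDr cells (Homo sapiens) for inhibition, read by sulforhodamine B assay, with a stated time of 48 h (a lower number here means a stronger inhibitor of growth, a higher number a weaker inhibitor of growth), compound 1 reaches only the limit of the assay, > 100000 nM. For the measured compounds named here, compound 2 gives 33000 nM, the single numerical value of the set. Compound 3 again stops at the limit, > 100000 nM. The steps read an at least 3.0-fold lower number from compound 1 to compound 2 (0.48 log units; beyond the scatter), an at least 3.0-fold higher number from compound 2 to compound 3 (0.48 log units; beyond the scatter) and a step that the two limits leave unreadable from compound 1 to compound 3. Compound 3 therefore stands at the limit of > 100000 nM in this assay, at which 2 of the 3 values shown sit, the position of the weakest readable growth inhibition in the set; its tie with compound 1 cannot be ordered.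

Compound 4 `O=C(CCCc1cc2ccccc2[nH]1)OCC1COCCOCCOCCOCCOCCO1` is the next case. The change is 1H-indol-2-yl in place of phenoxymethyl on a saturated chain carbon, three bonds along the chain from a carbonyl carbon. Going by the values given here, no measured step exchanges an aromatic ether for a fused bicyclic aromatic group, so the bearing evidence is indirect: the step from compound 2 to compound 3 showed that the phenoxy terminus sits at the limit, and the step from compound 1 to compound 3 was unreadable. Among the compounds with values here, removing the phenoxy terminus is the only element with a precedent, and that precedent was at least modest.

Compound 4 is expected to give 60000 nM, with a range from 15000 nM to 150000 nM. This estimate would mean an at least 1.6-fold lower number from compound 3 to compound 4 (0.22 log units; that floor lies within the scatter).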

Compound 4, concentration for 50% growth inhibition: > 100000 nM
Compound 4: only a limit was reported (the forecaster's own chance of this, stated with the estimate: 45%); at least 1.6-fold (0.22 log units) between middle value and limit.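

The exchange of cyclohexylmethyl for 1H-indol-2-yl on a saturated chain carbon, three bonds along the chain from a carbonyl carbon, gives an at least 3.0-fold higher number from compound 2 to compound 4 (0.48 log units; beyond the scatter). The steps that link compound 4 to compound 3 and to compound 1 cannot be read, as each has a limit at both ends. The result adds a fused bicyclic terminus with a hydrogen-bond donor to the aromatic termini of compound 1 and compound 3, none of which gives a numerical value in this assay, so among the compounds shown only the cyclohexyl terminus of compound 2 falls short of the limit, and no compound goes against this: the limit of > 100000 nM in this assay, at which 3 of the 4 values shown sit.

As far as these compounds go, how the three limited compounds would order among themselves stays open, and so does whether the indole itself matters at this place, as opposed to any aromatic terminus. Also open, from the compounds shown here alone, is whether a longer chain ending in cyclohexyl, or an amine at the chain end, would change the value of compound 2, 33000 nM.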